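The source may hold more compounds than are shown below. What is called first, only, known or untested is meant among the compounds shown, and "the series" means these compounds.

Working notes on the series. Compound 1 `O=C1N/C(=N/c2ccccc2)S/C1=C\c1ccccn1` carries an unsubstituted phenyl on the double-bonded nitrogen of the shared core; in a functional assay on the whole organism (strain Swiss albino) for inhibition, with Mus musculus as the target, in the writhing test, with stated times of 30 min and 15 min, at a dose of 50 mg/kg by the oral route (a lower number here means less inhibition, a higher number more inhibition at the dose given (going by the name of the read-out)), compound 1 gives 29.2%. Compound 2 `Cc1cccc(/N=C2/NC(=O)/C(=C/c3ccccn3)S2)c1` gives 52.3%, and compound 3 `O=C1N/C(=N/c2ccccc2Cl)S/C1=C\c1ccccn1` gives 36.2%. Among these three numbers compound 3 stands second highest: its nearest neighbour is compound 1, and the step of a number 7 percentage points higher from compound 1 to compound 3 (within the scatter) is within the scatter, while the step of a number 16.1 percentage points lower from compound 2 to compound 3 (beyond the scatter) separates it from compound 2.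

Compound 4 `O=C1N/C(=N/c2ccc(Br)cc2)S/C1=C\c1ccccn1` differs from compound 3 by 4-bromophenyl in place of 2-chlorophenyl on a double-bonded nitrogen. The measured steps that bear on this are the halogen step a number 7 percentage points higher from compound 1 to compound 3 (within the scatter), which stayed within the scatter, and the aryl swap a number 16.1 percentage points lower from compound 2 to compound 3 (beyond the scatter), which was modest; the methyl step a number 23.1 percentage points higher from compound 1 to compound 2 (beyond the scatter) concerns a different group. A halogen on the phenyl has so far not moved the read-out beyond the scatter, so no step beyond the scatter is expected here. Compound 4 is therefore estimated at 36%, with a range from 20% to 52%. This estimate corresponds to an expected step of a number 0.2 percentage points lower from compound 3 to compound 4 (within the scatter).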

Compound 4, a percentage reported as inhibition, in the whole organism at one dose (the size of the read-out at that dose, not a potency): 28.7%
Estimate against measurement, compound 4: 7.3 percentage points above; the measured number falls inside the stated range.
By their numbers in this assay, from the lowest: compounds 4, 1 and 3 (each within the scatter of the next); then compound 2.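

In this assay, 4-bromophenyl on the double-bonded nitrogen does not separate from unsubstituted phenyl (a number 0.5 percentage points lower from compound 1 to compound 4 (within the scatter)) or from 2-chlorophenyl (a number 7.5 percentage points lower from compound 3 to compound 4 (within the scatter)), so a second halogen-bearing aryl group now stays within the scatter of both. Within the data shown here, the step (a number 23.6 percentage points lower from compound 2 to compound 4 (beyond the scatter)) shows that 3-methylphenyl also stands clear of this third aryl group, leaving compound 2 as the one compound apart from compounds 1, 3 and 4. No available data explain this separation.

Since 2-chlorophenyl and 4-bromophenyl differ in both halogen and ring placement, the two changes cannot be told apart here. As far as these compounds go, it remains open whether 3-bromophenyl, 4-methylphenyl, 3-methoxyphenyl or 3-aminophenyl would stand with compound 2 or with the other three.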